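The source may report more compounds than this note shows. Statements on the series, on what has been measured and on what is new or still open speak of the compounds shown alone.

For the measured compounds named here, compound 2 `O=C(CSc1nc2c(c(=O)n1-c1ccccc1)SCC2)Nc1ccc(-c2cccnc2)cc1` in an assay on L cells for inhibition of Protein-serine O-palmitoleoyltransferase porcupine (Mus musculus), read by reporter gene assay, with a stated time of 24 h (a higher number here means that more compound is needed for the effect, a lower number that less compound is needed), gives 0.45 nM, the only numerical value so far. Compound 1 `CCOC(=O)c1ccc2nc(NC(=O)CNC(=O)c3nn(-c4ccccc4)c(=O)c4ccccc34)sc2c1` in this assay gives > 25000 nM, which is a limit of the assay and not a number. Compound 3 `CCOC(=O)c1ccc(NC(=O)CSc2nc3c(c(=O)n2-c2ccccc2)SCC3)cc1` carries ethoxycarbonyl in place of pyridin-3-yl on an aromatic carbon, ethoxycarbonyl in place of pyridin-3-yl on an aromatic carbon. Going by the values given here, no measured step of this kind exists, so its size is open; a loss of potency beyond the scatter is expected. The step of a 110-fold higher number from compound 2 to compound 3 (2.05 log units; beyond the scatter) is the expected change in this assay. Compound 3 is expected at 50 nM, with a range of 5 nM to 1000 nM.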

Compound 3, half-maximal effective concentration: 300 nM
For compound 3 the middle estimate is 6.0-fold (0.78 log units) below the measured one, within the range that was stated.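

In this assay, ethoxycarbonyl in place of pyridin-3-yl on the aromatic carbon para to a large group gives a 670-fold higher number from compound 2 to compound 3 (2.82 log units; beyond the scatter), so this position is sensitive to the group it carries. Even without the ring, compound 3 gives 300 nM, a number and not a limit of the assay. No measurement shown accounts for the size of this step.

Going by these compounds, whether the step follows from losing the ring or from bringing in the ester stays open. A pyridin-4-yl, a carboxylic acid or a primary amide at this position would help separate the two.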